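A new aromatic group on the sulfur of compound 3

The compounds below may be only part of what the source reports. "The series", "measured", "known", "first", "only" and "open" are said of these compounds alone.

In a functional assay on HeLa cells (Homo sapiens) for inhibition, read by CCK-8 assay, with a stated time of 72 h, tested at 2 uM (on this read-out higher numbers stand for more inhibition of growth at the one concentration tested and lower numbers for less inhibition of growth), compound 1 (`COc1ccc(SCc2ccc(C(=O)Nc3ccccc3N)cc2)cc1`) gives 35% and compound 2 (`Nc1ccccc1NC(=O)c1ccc(CSc2ccc(F)cc2)cc1`) gives 27.9% while compound 3 (`Nc1ccccc1NC(=O)c1ccc(CSc2ccc(Cl)cc2)cc1`) gives 19.2% as its reading. Compound 3 stands clear of compound 1, the step being a number 15.8 percentage points lower from compound 1 to compound 3 (beyond the scatter) and it cannot be told apart from compound 2, the step being a number 8.7 percentage points lower from compound 2 to compound 3 (within the scatter) in this case. The remaining step is a number 7.1 percentage points lower from compound 1 to compound 2 (within the scatter) and it too concerns a single group on the aromatic ring.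

Compound 4 (`Cc1cc(C)cc(SCc2ccc(C(=O)Nc3ccccc3N)cc2)c1`) has 3,5-dimethylphenyl in place of 4-chlorophenyl on a sulfur. Among the compounds with values here, no measured compound carries this group, so the three steps above offer only a guide to size, and the largest of them is the one from compound 1 to compound 3 (a number 15.8 percentage points lower from compound 1 to compound 3 (beyond the scatter)). With compound 3 at 19.2% there is more room upward than downward among these values, so a small rise is expected. The expected change is a number 7.8 percentage points higher from compound 3 to compound 4 (within the scatter) and may prove no larger than the scatter. For compound 4 the estimated value is 27% (expected range 14% to 41%).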

Compound 4, percent growth inhibition at one concentration: 40.2%
The estimate for compound 4 lay 13.2 percentage points below the measured number; the range from low to high includes it.
By their numbers in this assay, from the lowest: compounds 3, 2, 1 and 4 (each within the scatter of the next, the first and the last beyond it).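

In this assay the move from 4-chlorophenyl to 3,5-dimethylphenyl on the sulfur is a clear gain (a number 21 percentage points higher from compound 3 to compound 4 (beyond the scatter)), and the same holds for the move from 4-fluorophenyl (a number 12.3 percentage points higher from compound 2 to compound 4 (beyond the scatter)). Against 4-methoxyphenyl the new group cannot be told apart (a number 5.2 percentage points higher from compound 1 to compound 4 (within the scatter)), so compound 1 and compound 4 read alike although their rings carry different groups in different places. The position on the sulfur therefore accepts a ring with two methyl groups without any loss relative to the best ring with a single group. No measurement here accounts for these differences. Within the data shown here, still open is whether 3-methylphenyl, with only one methyl group, would read like 3,5-dimethylphenyl, and how a pyridine ring or a naphthyl group on the sulfur would read.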